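A Selenium Swap on a Weak Fused-Ring Antiproliferative

The source may report more compounds than this note shows. Statements on the series, on what has been measured and on what is new or still open speak of the compounds shown alone.

compound 1 `COc1ccc(CNc2nc(SC)nc3ncccc23)cc1`: 48100 nM
compound 2 `Nc1nc([SeH])nc2ncccc12`: 37300 nM

In a functional assay on MCF7 cells (Homo sapiens) for cytotoxicity, read by MTT assay, with a stated time of 72 h (a lower number here means a stronger inhibitor of growth, a higher number a weaker inhibitor of growth), compound 1 gives 48100 nM and compound 2 gives 37300 nM. Compound 2 shows the lower of the two numbers, yet the gap to compound 1 is within the scatter, so no order between them is established. Compound 3 `[SeH]c1nc([SeH])c2cccnc2n1` differs from compound 2 by one selenium atom in place of one nitrogen atom, on an aromatic carbon. Among the compounds with values here, no measured pair shows this change, so the step of a 1.2-fold lower number from compound 2 to compound 3 (0.07 log units; within the scatter) is expected to be small, with no direction beyond the scatter. Compound 3 is therefore expected at 32000 nM, within a range from 8000 nM to 120000 nM.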

Compound 3, concentration for 50% growth inhibition: 9830 nM
For compound 3 the middle estimate is 3.3-fold (0.51 log units) above the measured one; the range from low to high includes it.
By their numbers in this assay, from the lowest: compound 3; then compounds 2 and 1 (each within the scatter of the next).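

In this assay, within the data shown here, the swap of the amino group for a selenium atom on this aromatic carbon comes with a 3.8-fold lower number from compound 2 to compound 3 (0.58 log units; beyond the scatter), a modest step and the first change in this set that reads beyond the scatter. This position is therefore not indifferent to what it carries, and the amino group is not required to retain the growth inhibition seen with compound 2. No measurement here accounts for the shift.

From the compounds shown here alone, whether the selenium atom itself or the loss of the amino group carries the step remains open. So does how a hydroxyl group or a methylamine on this carbon would read.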